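The source may hold more compounds than are shown below. What is called first, only, known or untested is meant among the compounds shown, and "the series" means these compounds.

Measured so far:
compound 1, `CCCC/N=C(\NC#N)Nc1cccnc1`: 20 mg/kg
compound 2, `CCCC(C)(C)/N=C(\NC#N)Nc1cccnc1`: 1 mg/kg
compound 3, `N#CN/C(=N\Cc1ccco1)Nc1cccnc1`: 20 mg/kg

These three compounds share one core and differ only in the group carried on a double-bonded nitrogen. They were tested in a functional assay on the whole organism (blood, strain Wistar-Okamoto) with Rattus norvegicus as the target, with a stated time of 5 days; on this read-out lower numbers stand for an effect already at smaller amounts and higher numbers for an effect only at larger amounts of compound. In this assay compound 1 gives 20 mg/kg and sits level with compound 3, the two together making up the highest numbers of the three; its nearest neighbour is compound 3, since no change at the digits printed from compound 1 to compound 3 (within the scatter), and its furthest is compound 2, since a 20-fold lower number from compound 1 to compound 2 (1.30 log units; beyond the scatter).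

Compound 4, `N#CN/C(=N\c1ccccc1)Nc1cccnc1`, has not been measured. Compared with compound 1 its change is phenyl in place of butyl on a double-bonded nitrogen. Two measured steps speak to this. The step of a 20-fold lower number from compound 1 to compound 2 (1.30 log units; beyond the scatter) came from 1,1-dimethylbutyl in place of butyl on that nitrogen, a very different kind of change from a ring entering. The step of no change at the digits printed from compound 1 to compound 3 (within the scatter) came from furan-2-yl in place of propyl on a saturated chain carbon bound to the nitrogen, so a ring entered without moving the number. Among the compounds with values here, the ring in compound 4 sits directly on the nitrogen rather than one carbon away, which no measured pair covers, so the closer guide is the step to compound 3. For compound 4 a step of no change at the digits printed from compound 1 to compound 4 (within the scatter) is therefore expected, that is, nothing beyond the scatter. Compound 4 is estimated at 20 mg/kg, with a range from 5 mg/kg to 80 mg/kg.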

Compound 4, minimum effective dose: 5 mg/kg
The estimate for compound 4 lay 4.0-fold (0.60 log units) above the measured number, and the stated range covers the measured number.
By their numbers in this assay, from the lowest: compound 2; then compound 4; then compounds 1 and 3 (each within the scatter of the next).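

In this assay, a ring set directly on the double-bonded nitrogen does move the number, which the furan-2-yl ring held one carbon away in compound 3 did not do: phenyl in place of butyl gives a modest shift (a 4.0-fold lower number from compound 1 to compound 4 (0.60 log units; beyond the scatter)), and phenyl in place of (furan-2-yl)methyl gives a shift of the same printed size (a 4.0-fold lower number from compound 3 to compound 4 (0.60 log units; beyond the scatter)). Phenyl still does not match the branched 1,1-dimethylbutyl group, as the step back up shows (a 5.0-fold higher number from compound 2 to compound 4 (0.70 log units; beyond the scatter)), so this position responds to both a directly attached ring and a branched chain, with the chain giving the lowest number of the four compounds. No measurement here explains why either change lowers the number.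

The compounds shown leave open whether the shift depends on the ring being aromatic, which cyclohexyl on the same nitrogen would test, or on its distance from the nitrogen, which benzyl would test against both phenyl and (furan-2-yl)methyl. They also leave open how substituents on the phenyl ring, such as a chlorine or a methoxy group, would change the number.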